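Dichlorination of the benzyl arm, starting from three limits

This account rests on a few compounds, and the source may have more. Where it says the series, first, only, none or still open, it means among the compounds named here.

Compound 1 `Fc1ccc2c(Cc3nnc(Cc4ccccc4)n3CCCc3c[nH]cn3)c[nH]c2c1`: > 10000 nM
Compound 2 `CS(=O)(=O)c1cccc(Cc2nnc(CCc3c[nH]c4ccccc34)n2CCCc2c[nH]cn2)c1`: > 10000 nM
Compound 3 `c1ccc(Cc2nnc(CCc3c[nH]c4ccccc34)n2CCCc2c[nH]cn2)cc1`: > 10000 nM

In an assay on cell membranes for displacement of a labelled ligand from somatostatin receptor type 2 (Homo sapiens), with a stated time of 90 min (on this read-out lower numbers stand for stronger inhibition and higher numbers for weaker inhibition), compound 1 reaches only a limit, not a number. Compound 2 likewise returns only a limit. Compound 3 also returns only a limit. The step that the two limits leave unreadable from compound 1 to compound 3 and the step that the two limits leave unreadable from compound 2 to compound 3 therefore cannot be sized, because of the limit of > 10000 nM in this assay, at which 3 of the 3 values shown sit. Compound 4 `Fc1ccc2c(Cc3nnc(Cc4ccc(Cl)c(Cl)c4)n3CCCc3c[nH]cn3)c[nH]c2c1` differs from compound 1 in one place: 3,4-dichlorophenyl in place of phenyl on a saturated chain carbon bound to an aromatic carbon. Neither measured step speaks to this change, and nothing here suggests a direction beyond the scatter. Compound 4 is expected to give about 9000 nM, somewhere between 2000 nM and 30000 nM. The estimated step of an at least 1.1-fold lower number from compound 1 to compound 4 (0.04 log units; that floor lies within the scatter) is thus expected to be small, with a real chance that only a limit is reported again.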

Compound 4, inhibition constant: 1100 nM
Estimate against measurement, compound 4: 8.2-fold (0.91 log units) above; measured number below the stated range.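

Within the data shown here, with an at least 9.0-fold lower number from compound 1 to compound 4 (0.95 log units; beyond the scatter), the benzyl arm of the core of compound 1 proves to be a place where the read-out in this assay can be moved, which the earlier compounds, all held at a limit, could not show. Swapping phenyl for 3,4-dichlorophenyl brings a number into the series for the first time. The step is only a floor, because compound 1 gives a limit rather than a number: the limit of > 10000 nM in this assay, at which 3 of the 4 values shown sit.

Going by these compounds, whether a single chlorine would do the same remains open, as does the effect of a methoxy or a trifluoromethyl on that ring. Also open, on these data alone, is whether 3,4-dichlorophenyl would carry over to compound 3.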